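Chloro for methoxy on the shared indole core

The source may report more compounds than this note shows. Statements on the series, on what has been measured and on what is new or still open speak of the compounds shown alone.

Measured compounds:
compound 1, `Cc1ncccc1-c1cc2cc(CCC(=O)O)ccc2[nH]1`, > 25 nM
compound 2, `COc1ccccc1-c1cc2cc(CCC(=O)O)ccc2[nH]1`, > 25 nM

Compound 2 carries the structure `COc1ccccc1-c1cc2cc(CCC(=O)O)ccc2[nH]1`. In a functional assay on CHO cells for agonist activity at Free fatty acid receptor 1 (Homo sapiens), read by a luciferase reporter, with a stated time of 24 h (a lower number here means that less compound is needed, a higher number that more compound is needed for the effect), compound 2 gives > 25 nM, and this is a limit of the assay rather than a number. Compound 1, with the structure `Cc1ncccc1-c1cc2cc(CCC(=O)O)ccc2[nH]1`, also returns only a limit, > 25 nM, in this assay. Both values shown therefore sit at the same boundary, as the limit of > 25 nM in this assay, at which 2 of the 2 values shown sit, records, so nothing can be said about where compound 2 stands relative to compound 1 beyond the fact that both are limits.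

Compound 3, `O=C(O)CCc1ccc2[nH]c(-c3ccccc3Cl)cc2c1`, has not yet been tested in this assay. It differs from compound 2 in one place: chloro in place of methoxy on an aromatic carbon. Going by the values given here, no step between measured compounds is known, so there is no measured guide for the size of this change; the account expects a step that the limit leaves unreadable from compound 2 to compound 3, which is within the usual scatter. Compound 3 is therefore estimated at 40 nM in this assay, with a range from 12 nM to 150 nM.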

Compound 3, half-maximal effective concentration: 54.6 nM
Estimate against measurement, compound 3: 1.4-fold (0.14 log units) below; the measured number falls inside the stated range.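

No step can be read from compound 2 to compound 3 or from compound 1 to compound 3, because compound 1 and compound 2 return only limits in this assay: the limit of > 25 nM in this assay, at which 2 of the 3 values shown sit. The compounds shown leave open whether chloro in place of methoxy changes the value at all, and in which direction.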